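This account rests on a few compounds, and the source may have more. Where it says the series, first, only, none or still open, it means among the compounds named here.

The measured compounds so far:

Compound 1, `O=C(O)CCc1ccncc1-c1ccc2ccccc2c1`, in a functional assay on MCF7 cells (Homo sapiens) for inhibition, read by sulforhodamine B assay, with a stated time of 72 h (a lower number here means a stronger inhibitor of growth, a higher number a weaker inhibitor of growth), gives > 10000 nM, which is a limit of the assay and not a number.
Compound 2, `CN1CCN(C(=O)/C=C/c2ccncc2-c2ccc3ccccc3c2)CC1`, in this assay gives > 10000 nM, again a limit rather than a number.
Compound 3, `CN(C)C(=O)/C=C/c1ccncc1-c1ccc2ccccc2c1`, in this assay gives 8190 nM.

Going by the values given here, compound 3 therefore stands as the only member of this set with an actual number; the other two sit at the limit of > 10000 nM in this assay, at which 2 of the 3 values shown sit. The two steps that lead to it are an at least 1.2-fold lower number from compound 1 to compound 3 (0.08 log units; that floor lies within the scatter) and an at least 1.2-fold lower number from compound 2 to compound 3 (0.08 log units; that floor lies within the scatter), and in each case the floor of the step lies within the scatter, so neither shows a change that can be called real.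

Compound 4, `CCOC(=O)/C=C/c1ccncc1-c1ccc2ccccc2c1`, follows from compound 3 by one change: ethoxy in place of dimethylamino on a carbonyl carbon. Among the compounds with values here, of the measured steps, the one from compound 2 to compound 3 bears most directly on it, as it is also a swap on the same carbonyl carbon, and it produced only a floor within the scatter. Within the data shown here, with no step in this set beyond the scatter, the expected movement from compound 3 to compound 4 in this assay is none beyond the scatter, that is a 1.0-fold lower number from compound 3 to compound 4 (0.01 log units; within the scatter). Compound 4 is accordingly estimated at 8000 nM, with a range from 3000 nM to 20000 nM.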

Compound 4, concentration for 50% growth inhibition: 8320 nM
Beside the measured number, compound 4's estimate is 1.0-fold (0.02 log units) below it, within the range that was stated.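

Going by these compounds alone, the swap on this carbonyl carbon, whose other neighbour is a double-bonded chain carbon, gives the first step in this set with an actual number at both ends: in this assay it is a 1.0-fold higher number from compound 3 to compound 4 (0.01 log units; within the scatter). Ethoxy and dimethylamino therefore cannot be told apart here, even though ethoxy carries a hydrogen-bond acceptor and dimethylamino does not. The steps of an at least 1.2-fold lower number from compound 2 to compound 4 (0.07 log units; that floor lies within the scatter) and an at least 1.2-fold lower number from compound 1 to compound 4 (0.07 log units; that floor lies within the scatter) remain floors only, because their starting values are limits of the assay and not numbers: the limit of > 10000 nM in this assay, at which 2 of the 4 values shown sit.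

The compounds shown leave open whether a primary amide, a secondary amide or a hydroxamic acid on this carbonyl carbon would separate from compound 3 and compound 4 by more than the scatter. They also leave open how a free carboxylic acid on the ethenyl chain, or a saturated ethyl chain ending in the ethyl ester, would read, since the step from compound 1 alters both the chain and its end group at once.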